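Fluoro removal on the pendant aryl ring of compound 1

The compounds below may be only part of what the source reports. "The series", "measured", "known", "first", "only" and "open" are said of these compounds alone.

Compound 1 `COc1cc(-n2cnc3ccc(-c4ccc(C)cc4F)cc32)cc(OC)c1OC`: > 10000 nM
Compound 2 `COc1cc(-n2cnc3ccc(-c4cccc(C)c4)cc32)cc(OC)c1OC`: 3820 nM

In a functional assay on A549 cells (Homo sapiens) for antiproliferative activity, read by MTT assay, with a stated time of 72 h (a lower number here means a stronger inhibitor, a higher number a weaker inhibitor), compound 1 gives > 10000 nM, which is a limit of the assay and not a number. Among the measured compounds shown here, compound 2 is the only other member measured so far; in this assay compound 2 gives 3820 nM. For the measured compounds named here, the one measured step, an at least 2.6-fold lower number from compound 1 to compound 2 (0.41 log units; beyond the scatter), changes the whole pendant aryl group and is the only evidence on how this part of the shared core matters; it can be read only with the limit of > 10000 nM in this assay, at which 1 of the 2 values shown sits, in mind.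

Compound 3 `COc1cc(-n2cnc3ccc(-c4ccc(C)cc4)cc32)cc(OC)c1OC` differs from compound 1 by hydrogen in place of fluoro on an aromatic carbon. Going by the values given here, this is a smaller change than the one from compound 1 to compound 2, and the 4-methylphenyl of compound 3 sits between the two measured aryl groups. Among the compounds with values here, no measured step isolates the fluoro alone, so no direction beyond the scatter is firmly expected; a step of modest size toward compound 2 is possible, as is another limit.

For compound 3 the expected value in this assay is 8000 nM, within 3000 nM to 25000 nM, meaning an estimated step of an at least 1.2-fold lower number from compound 1 to compound 3 (0.09 log units; that floor lies within the scatter).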

Compound 3, half-maximal inhibitory concentration: 1940 nM
Beside the measured number, compound 3's estimate is 4.1-fold (0.62 log units) above it; the whole stated range lies above it.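

In this assay, the fluoro alone now proves to matter on this ring: hydrogen in its place gives an at least 5.1-fold lower number from compound 1 to compound 3 (0.71 log units; beyond the scatter), whereas the earlier step changed the whole pendant aryl group and could not separate the fluoro from the placing of the methyl. As far as these compounds go, compound 1 gives > 10000 nM, which is a limit of the assay and not a number, so the true size of this step stays unknown: the limit of > 10000 nM in this assay, at which 1 of the 3 values shown sits. The methyl's placing, by contrast, does not separate the two fluoro-free compounds, with a 2.0-fold lower number from compound 2 to compound 3 (0.29 log units; within the scatter), so 3-methylphenyl and 4-methylphenyl cannot be told apart in this assay.

Compound 1 is the only fluoro-bearing compound shown, so it remains open whether the fluoro has the same effect on a 3-methylphenyl group or at another place on the ring. Also open, from the compounds shown here alone, is whether the methyl is needed at all, and how a chloro, a methoxy or an amine in its place would read against the values of compound 2 and compound 3.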